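Swapping 4-methylbenzyl for 3-methylphenyl on the shared core

A few compounds are considered here, and "the series" means these few. Any claim that something is new, unique, unknown or untested is made for them only; others in the source may bear on it.

Compound 1 `Cc1ccccc1Nc1nc(NC2CCCCC2)ncc1Cl` gives > 100000 nM as a limit
Compound 2 `Cc1ccccc1Nc1nc(NCc2ccco2)ncc1Cl` gives > 100000 nM as a limit
Compound 3 `Cc1ccc(CNc2nc(Nc3ccc(N4CCN(C)CC4)cn3)ncc2Cl)cc1` gives 12700 nM as a number

Among the compounds with values here, compound 3 is the only compound with a true number in a functional assay on Jurkat cells (Homo sapiens) for inhibition, read by CCK-8 assay, with a stated time of 48 h (a lower number here means a stronger inhibitor of growth, a higher number a weaker inhibitor of growth), where compound 3 reads 12700 nM and so serves as the sole anchor. The other two values are limits, not numbers (the limit of > 100000 nM in this assay, at which 2 of the 3 values shown sit).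

Compound 4 `Cc1cccc(Nc2nc(Nc3ccc(N4CCN(C)CC4)cn3)ncc2Cl)c1` has not yet been measured. It keeps the rest of compound 3 and changes one group (3-methylphenyl in place of 4-methylbenzyl on a nitrogen on an aromatic ring): 3-methylphenyl in place of 4-methylbenzyl on a nitrogen on an aromatic ring.

Within the data shown here, the only measured step (a step that the two limits leave unreadable from compound 1 to compound 2) is a different change and offers no size to carry over. The expectation therefore rests on compound 3 at 12700 nM alone, and no shift beyond the scatter is expected in either direction. The expected change is a 1.3-fold lower number from compound 3 to compound 4 (0.10 log units; within the scatter) with no firm direction. The expected value for compound 4 in this assay is 10000 nM within a wide estimated range (from 1500 nM to 60000 nM).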

Compound 4, concentration for 50% growth inhibition: 15300 nM
Compound 4: middle estimate off by 1.5-fold (0.18 log units), on the low side, and the stated range covers the measured number.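

In this assay, within the data shown here, the swap gives the only readable step so far, a 1.2-fold higher number from compound 3 to compound 4 (0.08 log units; within the scatter), where the earlier step between two compounds could not be read. At this nitrogen on an aromatic ring, 3-methylphenyl and 4-methylbenzyl therefore cannot be told apart, even though the entering group has 7 heavy atoms and the leaving group 8. The data shown give no cause for this result.

Among these compounds, with only this one swap to read, it remains open whether any other group on this nitrogen would move the number beyond the scatter. A carboxylic acid or an amine on the benzene ring, or a longer chain between that ring and the nitrogen, could test this.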